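This account rests on a few compounds, and the source may have more. Where it says the series, first, only, none or still open, it means among the compounds named here.

Measured in a functional assay on HeLa cells (Homo sapiens) for antiproliferative activity, read by MTT assay, with a stated time of 72 h; a lower number here means a stronger inhibitor, a higher number a weaker inhibitor:
Compound 1 `C=CC(=O)Nc1cccc(Oc2nc(Nc3ccn(C)n3)nc3c2CSCC3)c1` gives 25800 nM.
Compound 2 `C/C=C/C(=O)Nc1cccc(Oc2nc(Nc3ccn(C)n3)nc3c2CSCC3)c1` reaches only the assay limit, > 50000 nM.
Compound 3 `CCC/C=C/C(=O)Nc1cccc(Oc2nc(Nc3ccn(C)n3)nc3c2CSCC3)c1` gives 17000 nM.

Compound 3 holds the lowest of the two numbers reported; the nearest is compound 1, with a 1.5-fold lower number from compound 1 to compound 3 (0.18 log units; within the scatter), a gap within the scatter. Compound 2 gives no number; its reading is a limit, (the limit of > 50000 nM in this assay, at which 1 of the 3 values shown sits). The step of an at least 1.9-fold higher number from compound 1 to compound 2 (0.28 log units; that floor lies within the scatter) and the step of an at least 2.9-fold lower number from compound 2 to compound 3 (0.46 log units; beyond the scatter) both run through that limit, so only their floors are known.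

Compound 4 `CC(C)/C=C/C(=O)Nc1cccc(Oc2nc(Nc3ccn(C)n3)nc3c2CSCC3)c1` is the next member. It differs from compound 3 as follows: isopropyl in place of propyl on a double-bonded chain carbon bound to a double-bonded chain carbon. Among the measured compounds shown here, the steps measured so far all alter the length of the chain on the carbonyl carbon, from vinyl to prop-1-en-1-yl and to pent-1-en-1-yl; none rearranges the same atoms into a branched chain, so no measured step maps directly onto this change. The numbers for compound 1 and compound 3 sit within scatter of each other, and the change in chain length between them has given no step beyond scatter. For compound 4 the expected step from compound 3 is no change at the digits printed from compound 3 to compound 4 (within the scatter), no change beyond the scatter. Compound 4 is estimated at 17000 nM in this assay, with a range of 8000 nM to 40000 nM.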

Compound 4, half-maximal inhibitory concentration: 40100 nM
For compound 4 the middle estimate is 2.4-fold (0.37 log units) below the measured one; measured number above the stated range.
By their numbers in this assay, from the lowest: compounds 3, 1 and 4 (each within the scatter of the next, the first and the last beyond it). At a limit, above all of these: compound 2.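

In this assay, among the compounds shown here, a 2.4-fold higher number from compound 3 to compound 4 (0.37 log units; beyond the scatter) is the first step beyond the scatter that does not run through a limit: pent-1-en-1-yl gives way to 3-methylbut-1-en-1-yl, the same atoms joined differently, so at this place the branching of the chain alters the reading even though the heavy-atom count stays the same. The branched chain is separated from the unbranched propyl-bearing chain but not from vinyl, with a 1.6-fold higher number from compound 1 to compound 4 (0.19 log units; within the scatter), so this series gives no simple order running from vinyl through longer or branched chains. The remaining step, an at least 1.2-fold lower number from compound 2 to compound 4 (0.09 log units; that floor lies within the scatter), runs through an assay limit, so only its floor is known and it cannot be read as a size: the limit of > 50000 nM in this assay, at which 1 of the 4 values shown sits.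

The compounds shown leave open whether a tert-butyl or cyclopropyl group on this double-bonded chain carbon would read like isopropyl or like propyl, and whether a dimethylamino group on the chain would move the number at all. A single cell read-out also cannot tell what lies behind the step from propyl to isopropyl.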